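A few compounds are considered here, and "the series" means these few. Any claim that something is new, unique, unknown or untested is made for them only; others in the source may bear on it.

For the measured compounds named here, compound 2 `FC(F)(F)c1ccc(Nc2cc3[nH]c(C4CCCC4)nc3cn2)nc1` gives 145000 nM in a physicochemical assay for solubility, using the shake flask method, in phosphate buffer, measured as kinetic solubility, with a stated time of 20 h, at pH 6.5 (on this read-out higher numbers stand for higher solubility and lower numbers for lower solubility), the only true number so far. Compound 1 `FC(F)(F)c1ccc(Nc2cc3[nH]c(-c4cccc(C(F)(F)F)c4)nc3cn2)nc1` gives < 5000 nM, which is a limit of the assay and not a number.

The next structure is compound 3 `FC1(F)CCC(c2nc3cnc(Nc4ccc(C(F)(F)F)cn4)cc3[nH]2)C1`, and the change is 3,3-difluorocyclopentyl in place of cyclopentyl on an aromatic carbon. In words, 3,3-difluorocyclopentyl takes the place of cyclopentyl on an aromatic carbon of the five-membered aromatic ring, between two ring nitrogen atoms. The rest of the structure stays the same.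

Going by the values given here, one measured step bears on this: an at least 29-fold higher number from compound 1 to compound 2 (1.46 log units; beyond the scatter). It is large, but it replaced 3-(trifluoromethyl)phenyl with cyclopentyl, a different exchange from the one here. Its size is only a bound, set by the limit of < 5000 nM in this assay, at which 1 of the 2 values shown sits. The cyclopentyl of compound 2 keeps its five-membered ring in compound 3, so a much smaller shift than an at least 29-fold higher number from compound 1 to compound 2 (1.46 log units; beyond the scatter) is expected in this assay, with a slight drop at most and probably nothing beyond the scatter.

The estimated step is a 1.5-fold lower number from compound 2 to compound 3 (0.16 log units; within the scatter). For compound 3 the expected value is 100000 nM, with an estimated range of 35000 nM to 200000 nM.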

Compound 3, solubility: 120000 nM
Compound 3: middle estimate off by 1.2-fold (0.08 log units), on the low side; the range from low to high includes it.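

At this aromatic carbon of the five-membered ring, between two ring nitrogen atoms, the exchange of cyclopentyl for 3,3-difluorocyclopentyl gives no difference that stands out from the scatter in this assay: a 1.2-fold lower number from compound 2 to compound 3 (0.08 log units; within the scatter). The large step from the aryl group is also no longer tied to cyclopentyl alone, since a second five-membered non-aromatic ring in place of 3-(trifluoromethyl)phenyl gives an at least 24-fold higher number from compound 1 to compound 3 (1.38 log units; beyond the scatter). Compound 1 sits at a limit of the assay and not at a number, so this step, like the earlier one, holds only as a bound: the limit of < 5000 nM in this assay, at which 1 of the 3 values shown sits.

The compounds shown leave open whether this position stays as tolerant in this assay with a ring or chain of another kind, such as a morpholine, a piperidine carrying an amine, a cyclopentyl bearing a carboxylic acid, or an open butyl chain. They also leave open whether any exchange among non-aromatic groups at this carbon moves the number beyond the scatter, as only cyclopentyl and 3,3-difluorocyclopentyl can be compared here.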